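Para-substituent swap on a hydrazone growth inhibitor

The source may hold more compounds than are shown below. What is called first, only, known or untested is meant among the compounds shown, and "the series" means these compounds.

Measured compounds:
Compound 1, `Cc1ccc(/C=N\NC(=O)C2=C(Cl)c3ccccc3CCC2)cc1`, gives < 10 nM in a functional assay (MiaPaCa cells, Homo sapiens) for inhibition, read by sulforhodamine B assay, with a stated time of 48 h (on this read-out higher numbers stand for weaker inhibition of growth and lower numbers for stronger inhibition of growth), a limit of the assay.
Compound 2, `COc1cc(/C=N\NC(=O)C2=C(Cl)c3ccccc3CCC2)cc(OC)c1OC`, gives 1400 nM in this assay.
Compound 3, `O=C(N/N=C\c1ccc(Cl)cc1)C1=C(Cl)c2ccccc2CCC1`, gives < 10 nM in this assay, a limit of the assay.

Compound 1 therefore stands at a limit rather than at a number, and one other compound stands at the same limit, so no ranking between them can be read. Going by the values given here, compound 2 is the only compound with a full number, and it sits far above that limit.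

Compound 4, `O=C(N/N=C\c1ccc(F)cc1)C1=C(Cl)c2ccccc2CCC1`, has not been measured. It differs from compound 1 by fluoro in place of methyl on an aromatic carbon. Among the compounds with values here, the only step that touches the same position is a step that the two limits leave unreadable from compound 1 to compound 3, and its size is hidden because both ends sit at the limit of < 10 nM in this assay, at which 2 of the 3 values shown sit. Within the data shown here, the one step that bears on it thus gives no size and no direction. Because two of the three values sit at the limit of < 10 nM in this assay, at which 2 of the 3 values shown sit, compound 4 is expected to land near the same limit, with a step that the limit leaves unreadable from compound 1 to compound 4 expected to be no larger than the scatter. Compound 4 is estimated at 8 nM in this assay, within 2 nM to 35 nM.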

Compound 4, concentration for 50% growth inhibition: < 10 nM
Compound 4 gave a limit, no number; the forecaster's own chance of this, stated with the estimate: 60%; the middle value is on the limit's open side.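

No step among compound 1, compound 3 and compound 4 can be read, because all three stand at the same limit of the assay rather than at a number: the limit of < 10 nM in this assay, at which 3 of the 4 values shown sit.

The compounds shown leave open whether methyl, chloro and fluoro differ at all in this assay.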